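Swapping the Alkyne Cap from Pyridine to Cyclopropane

The compounds below may be only part of what the source reports. "The series", "measured", "known", "first", "only" and "open" are said of these compounds alone.

Measured compounds:
compound 1, `C[C@@H](NC(=O)c1ccc(C#Cc2ccc(F)cc2)cn1)C(C)(C)O`, 66.2%
compound 2, `Cc1ccccc1C#Cc1ccc(C(=O)N[C@H](C)C(C)(C)O)nc1`, 59.9%
compound 3, `C[C@@H](NC(=O)c1ccc(C#Cc2ccncc2)cn1)C(C)(C)O`, 66.6%

All three share one core and differ only in the group on the triple-bonded carbon. In a functional assay on HEK293 cells for positive allosteric modulation of metabotropic glutamate receptor 5 (Rattus norvegicus), read by fluorescence and calcium flux (a lower number here means a smaller maximal response, a higher number a larger maximal response), compound 3 gives 66.6%, the highest of the three numbers, yet the step of a number 0.4 percentage points higher from compound 1 to compound 3 (within the scatter) and the step of a number 6.7 percentage points higher from compound 2 to compound 3 (within the scatter) both stay within the scatter, so the three compounds cannot be told apart on this read-out.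

Compound 4, `C[C@@H](NC(=O)c1ccc(C#CC2CC2)cn1)C(C)(C)O`, has not yet been measured. Its change from compound 3 is cyclopropyl in place of pyridin-4-yl on a triple-bonded carbon. All three measured steps touch exactly this position, and each was within the scatter: a number 6.3 percentage points lower from compound 1 to compound 2 (within the scatter), a number 0.4 percentage points higher from compound 1 to compound 3 (within the scatter), a number 6.7 percentage points higher from compound 2 to compound 3 (within the scatter). None of them, however, exchanges an aromatic ring for a small non-aromatic ring, so the guidance is indirect. The expectation for this assay is therefore a step of a number 4.6 percentage points lower from compound 3 to compound 4 (within the scatter), not beyond the scatter, with a wider range than the measured spread. Compound 4 is estimated at 62%, between 47% and 76%.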

Compound 4, largest response reached (reported as efficacy), in percent of the reference or control that the assay uses: 63.4%
For compound 4 the middle estimate is 1.4 percentage points below the measured one, within the range that was stated.
By their numbers in this assay, from the lowest: compounds 2, 4, 1 and 3 (each within the scatter of the next).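

Here an aromatic ring on the triple-bonded carbon gives way to cyclopropyl, a three-membered non-aromatic ring of carbon only, and this assay shows a number 3.2 percentage points lower from compound 3 to compound 4 (within the scatter). Measured against the other two aromatic groups, the change gives a number 3.5 percentage points higher from compound 2 to compound 4 (within the scatter) and a number 2.8 percentage points lower from compound 1 to compound 4 (within the scatter), so across these four compounds, this position accepts a non-aromatic ring as well as an aromatic one, with no difference that can be told apart on this read-out. Nothing available explains why the number stays so close across these groups.

As far as these compounds go, whether a group without any ring on this carbon, such as a longer alkyl chain or a chain ending in an amine, would give a step beyond the scatter remains open. From the compounds shown here alone, these numbers describe only the largest response reached, so how much of each compound is needed to reach it remains open too.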